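A few compounds are considered here, and "the series" means these few. Any claim that something is new, unique, unknown or untested is made for them only; others in the source may bear on it.

The study turns on three closely related structures that share one core. Compound 1 `CC(C)N(c1ccnc(Nc2ccc(C#N)cc2)n1)c1c(F)cc(-c2ccc(C#N)cc2)cc1F` carries an isopropyl group on the ring nitrogen, and in an ADME assay on MT4 cells (Homo sapiens) for cytotoxicity, read by MTT assay, with a stated time of 5 days (on this read-out higher numbers stand for lower toxicity in this test and lower numbers for higher toxicity in this test), compound 1 gives 172000 nM. Compound 2 `N#Cc1ccc(Nc2nccc(N(CC3CCCC3)c3c(F)cc(-c4ccc(C#N)cc4)cc3F)n2)cc1` has cyclopentylmethyl in that position. In this assay compound 2 reaches only a limit, > 247000 nM, so its place on the numbers is known just as a floor, as marked by the limit of > 247000 nM in this assay, at which 1 of the 2 values shown sits. Among the compounds with values here, the one measured step, an at least 1.4-fold higher number from compound 1 to compound 2 (0.15 log units; that floor lies within the scatter), is therefore bounded rather than fixed, and its floor sits within the scatter.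

Compound 3 `N#Cc1ccc(Nc2nccc(N(CCCF)c3c(F)cc(-c4ccc(C#N)cc4)cc3F)n2)cc1` differs from compound 2 by 2-fluoroethyl in place of cyclopentyl on a saturated chain carbon bound to a nitrogen on an aromatic ring. Within the data shown here, only the step from compound 1 to compound 2 bears on this change, and it shows no movement beyond the scatter between a small and a larger group on that nitrogen. Compound 3 is accordingly expected to move by an at least 1.2-fold lower number from compound 2 to compound 3 (0.09 log units; that floor lies within the scatter), no more than the scatter allows. The value estimated for compound 3 in this assay is 200000 nM, between 110000 nM and 300000 nM.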

Compound 3, half-maximal cytotoxic concentration: 241000 nM
For compound 3 the middle estimate is 1.2-fold (0.08 log units) below the measured one; the range from low to high includes it.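

In this assay the step is a 1.4-fold higher number from compound 1 to compound 3 (0.15 log units; within the scatter), so a fluorine-bearing open chain on this nitrogen gives a fully measured comparison, which the earlier pair offered only as a floor, and it stays within the scatter. Set against cyclopentylmethyl, the same chain gives an at least 1.0-fold lower number from compound 2 to compound 3 (0.01 log units; that floor lies within the scatter), so removing the ring from this group produces no movement that can be read beyond the scatter. That step remains only bounded, because compound 2 stands at a limit: the limit of > 247000 nM in this assay, at which 1 of the 3 values shown sits.

The compounds shown leave open whether an amine, a carboxylic acid or a much longer chain on this nitrogen would move the read-out beyond the scatter. As far as these compounds go, they also leave open whether a plain propyl chain would read the same as 3-fluoropropyl, so the fluorine's own contribution stays unknown.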